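Swapping 2-methyl-1H-indol-5-yl for 4-methoxyphenyl at the amine

The compounds below may be only part of what the source reports. "The series", "measured", "known", "first", "only" and "open" are said of these compounds alone.

Three compounds have been measured:
compound 1 `COc1ccc(N/C=C\C(=O)c2nc(-c3ccc(F)cc3)n3ccccc23)cc1OC` gives > 30000 nM
compound 2 `COc1ccc(-c2nc(C(=O)/C=C\Nc3ccc(F)cc3)c3ccccn23)cc1` gives > 30000 nM
compound 3 `Cc1cc2cc(N/C=C\C(=O)c3nc(-c4ccc(F)cc4)n4ccccc34)ccc2[nH]1` gives > 30000 nM

In a functional assay on B16-F10 cells (Mus musculus) for cytotoxicity, read by MTT assay, with a stated time of 48 h (on this read-out higher numbers stand for weaker inhibition and lower numbers for stronger inhibition), compound 3 reaches only a limit of the assay and not a number. Compound 1 sits at the same limit, so the step that the two limits leave unreadable from compound 1 to compound 3 cannot be read in size. The same holds across the whole set, as the limit of > 30000 nM in this assay, at which 3 of the 3 values shown sit, shows. Compound 4 `COc1ccc(N/C=C\C(=O)c2nc(-c3ccc(F)cc3)n3ccccc23)cc1` differs from compound 3 by 4-methoxyphenyl in place of 2-methyl-1H-indol-5-yl on an amine nitrogen. Going by the values given here, no measured step with a readable size bears on this change, and the three values so far all stand at the limit. Compound 4 is therefore expected to stay at the limit too. The expected step is a number no higher from compound 3 to compound 4 (the limit leaves the size open), nothing beyond the scatter. The estimate for compound 4 is 30000 nM, between 15000 nM and 60000 nM.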

Compound 4, half-maximal inhibitory concentration: 2560 nM
The estimate for compound 4 lay 12-fold (1.07 log units) above the measured number; the whole stated range lies above it.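

In this assay, the group on the amine nitrogen proves able to bring the series off its limit: 4-methoxyphenyl in place of 2-methyl-1H-indol-5-yl gives an at least 11-fold lower number from compound 3 to compound 4 (1.06 log units; beyond the scatter). Hydrogen in place of methoxy on an aromatic carbon gives an at least 11-fold lower number from compound 1 to compound 4 (1.06 log units; beyond the scatter), so a single methoxy group separates a readable number from the limit. Compound 4 alone gives a number, and the rest of the set stays at a limit: the limit of > 30000 nM in this assay, at which 3 of the 4 values shown sit.

The compounds shown leave open whether an ethoxy or a dimethylamino group in place of the remaining methoxy would keep this number. As far as these compounds go, whether a plain phenyl on the amine nitrogen would do so also stays open.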